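Trading carboxymethyl for phenyl on the chain amine

The source may hold more compounds than are shown below. What is called first, only, known or untested is meant among the compounds shown, and "the series" means these compounds.

For the measured compounds named here, in a functional assay on SK-BR-3 cells (Homo sapiens) for antiproliferative activity (on this read-out lower numbers stand for stronger inhibition and higher numbers for weaker inhibition), compound 2 `CC(C)=CCc1cc(C(=O)Nc2cc3ccc(OCCCNCC(=O)O)c(C)c3oc2=O)ccc1O` gives 7570 nM and is the only compound with a true number so far. Compound 1 `CC(C)=CCc1cc(C(=O)Nc2cc3ccc(OCCCN4CCCCC4)c(C)c3oc2=O)ccc1O` gives > 50000 nM and this is a limit of the assay, not a number. Compound 3 `CC(C)=CCc1cc(C(=O)Nc2cc3ccc(OCCCNc4ccccc4)c(C)c3oc2=O)ccc1O` is still unmeasured and carries phenyl in place of carboxymethyl on an amine nitrogen. Going by the values given here, one measured step bears on this: with (carboxymethyl)amino in place of piperidin-1-yl, the change gave an at least 6.6-fold lower number from compound 1 to compound 2 (0.81 log units; beyond the scatter) and so losing carboxymethyl is expected to cost some inhibition. The expected step is a 2.4-fold higher number from compound 2 to compound 3 (0.38 log units; beyond the scatter) towards weaker inhibition, although this rests on that single step alone. Compound 3 is estimated at 18000 nM with an expected range from 6000 nM to 50000 nM on this read-out.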

Compound 3, half-maximal inhibitory concentration: > 50000 nM
Compound 3 was reported as a limit (the forecaster's own chance of this, stated with the estimate: 30%); at least 2.7-fold (0.44 log units) between middle value and limit.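

In this assay, the swap of carboxymethyl for phenyl on the amine nitrogen gives an at least 6.6-fold higher number from compound 2 to compound 3 (0.81 log units; beyond the scatter), so a second group at this position now joins piperidin-1-yl in losing the measurable inhibition seen with compound 2. The value of compound 3 is a limit of the assay, and among the three compounds shown, only compound 2, with carboxymethyl on the chain amine, gives a true number. Compound 1 and compound 3 cannot be ranked against each other, because both sit at the same limit: the limit of > 50000 nM in this assay, at which 2 of the 3 values shown sit.

Still open, going by these compounds, is whether the carboxylic acid of carboxymethyl is itself what matters, or whether its methyl ester or primary amide would do as well. Equally open, on these data alone, is how a small group such as ethyl on the chain amine, or a longer 2-carboxyethyl group, would compare with compound 2.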